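Estimating a pyridylmethylamino analogue in a serotonin receptor binding series

This account rests on a few compounds, and the source may have more. Where it says the series, first, only, none or still open, it means among the compounds named here.

Measured so far:
- compound 1, `CC(=O)Nc1ccc(CNC2CCN(CCCc3c[nH]c4ccc(-n5cnnc5)cc34)CC2)cc1`: 3 nM
- compound 2, `CN(Cc1ccsc1)C1CCN(CCCc2c[nH]c3ccc(-n4cnnc4)cc23)CC1`: 1.5 nM
- compound 3, `C[C@H](NCC1CCN(CCCc2c[nH]c3ccc(-n4cnnc4)cc23)CC1)c1ccccc1`: 4.4 nM

All three compounds share a core and differ only in the group attached to a saturated ring carbon of the piperidine-like ring. Their numbers in an assay on CHO cells for displacement of a labelled ligand from 5-hydroxytryptamine receptor 1D (Homo sapiens) (a lower number here means a stronger inhibitor, a higher number a weaker inhibitor), lie close together. Compound 3 gives the highest of the three numbers; its gap to compound 1 lies within the usual scatter, while the step of a 2.9-fold higher number from compound 2 to compound 3 (0.47 log units; beyond the scatter) is modest but beyond it.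

Compound 4, `c1cncc(CNC2CCN(CCCc3c[nH]c4ccc(-n5cnnc5)cc34)CC2)c1`, is not yet measured. It differs from compound 3 in one place: ((pyridin-3-yl)methyl)amino in place of ((1-phenylethyl)amino)methyl on a saturated ring carbon. Among the measured compounds shown here, the only measured step that touches this position is the one from compound 2 to compound 3, and it is modest. For the measured compounds named here, no measured pair isolates the present change, but compound 1 carries a related arylmethylamino group on the same ring carbon and gives 3 nM, which sits within the scatter of compound 3.

On this basis compound 4 is expected to show a step of a 1.5-fold lower number from compound 3 to compound 4 (0.17 log units; within the scatter), not beyond the scatter. The estimate for compound 4 is therefore 3 nM, with a likely range from 1 nM to 10 nM.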

Compound 4, half-maximal inhibitory concentration: 35 nM
Compound 4: middle estimate off by 12-fold (1.07 log units), on the low side, and the stated range ends below it.
By their numbers in this assay, from the lowest: compounds 2, 1 and 3 (each within the scatter of the next, the first and the last beyond it); then compound 4.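

In this assay, the close numbers of compounds 1, 2 and 3 made the group on the saturated ring carbon look tolerant of change, but compound 4 shows that this tolerance has limits. The cleanest comparison keeps the amine and its chain carbon and swaps only 4-acetamidophenyl for pyridin-3-yl, giving a 12-fold higher number from compound 1 to compound 4 (1.07 log units; beyond the scatter) and showing that the aromatic ring at the end of this group matters, not just the presence of an arylmethylamino group. The wider swaps agree, with an 8.0-fold higher number from compound 3 to compound 4 (0.90 log units; beyond the scatter) and a 23-fold higher number from compound 2 to compound 4 (1.37 log units; beyond the scatter), so among these four compounds only compound 4, the one with a nitrogen in its aromatic ring, stands apart.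

Going by these compounds, it remains open whether that ring nitrogen matters in itself or whether the loss of the acetamido group counts for more, a question that a pyridin-4-yl or an unsubstituted phenyl group on the same chain carbon could help to answer. Nothing available here explains the higher number for compound 4.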